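Swapping Dimethylamino for Chlorine on the Saturated Ring Carbon

A few compounds are considered here, and "the series" means these few. Any claim that something is new, unique, unknown or untested is made for them only; others in the source may bear on it.

Three compounds share one core and differ only in the group attached to a saturated ring carbon. Compound 1 `COc1cc(/C=C/C(=O)C2=C(/C=C/c3ccc(O)c(OC)c3)NC(=S)NC2c2ccccc2)ccc1O` carries a plain phenyl; in a functional assay, with a stated time of 20 min, tested at 2 uM (on this read-out higher numbers stand for a stronger effect at the one concentration tested and lower numbers for a weaker effect), compound 1 gives 16.6%. Compound 2 `COc1cc(/C=C/C(=O)C2=C(/C=C/c3ccc(O)c(OC)c3)NC(=S)NC2c2ccc(C)cc2)ccc1O` has methyl in place of hydrogen on an aromatic carbon, and in this assay compound 2 gives 10.2%. Compound 3 `COc1cc(/C=C/C(=O)C2=C(/C=C/c3ccc(O)c(OC)c3)NC(=S)NC2c2ccc(N(C)C)cc2)ccc1O` has dimethylamino on that aromatic carbon, and in this assay compound 3 gives 32.3%, the highest of the three numbers.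

The steps tell a simple story: a number 6.4 percentage points lower from compound 1 to compound 2 (within the scatter), whereas a number 15.7 percentage points higher from compound 1 to compound 3 (beyond the scatter) and a number 22.1 percentage points higher from compound 2 to compound 3 (beyond the scatter). Only the dimethylamino group lifted the read-out beyond the scatter.

Compound 4 `COc1cc(/C=C/C(=O)C2=C(/C=C/c3ccc(O)c(OC)c3)NC(=S)NC2c2ccccc2Cl)ccc1O` is the next step: 2-chlorophenyl in place of 4-(dimethylamino)phenyl on a saturated ring carbon. The group that went with the highest number leaves, and 2-chlorophenyl, untested so far, enters. Given a number 15.7 percentage points higher from compound 1 to compound 3 (beyond the scatter), a fall back toward the range of compound 1 and compound 2 is expected, so compound 4 is estimated at 16%, between 5% and 30%. That expected change is a number 16.3 percentage points lower from compound 3 to compound 4 (beyond the scatter).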

Compound 4, a percentage reported as activity, at one concentration (the size of the read-out at that concentration, not a potency): 15.5%
Compound 4: the middle estimate sits 0.5 percentage points above what was measured; the range from low to high includes it.
By their numbers in this assay, from the lowest: compounds 2, 4 and 1 (each within the scatter of the next); then compound 3.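

In this assay, 2-chlorophenyl in place of 4-(dimethylamino)phenyl on the saturated ring carbon gives a number 16.8 percentage points lower from compound 3 to compound 4 (beyond the scatter) and shows that the higher number of compound 3 does not extend to every substituted phenyl at this position. Going from the plain phenyl to 2-chlorophenyl gives a number 1.1 percentage points lower from compound 1 to compound 4 (within the scatter) and 2-chlorophenyl in place of 4-methylphenyl gives a number 5.3 percentage points higher from compound 2 to compound 4 (within the scatter) so neither change separates compound 4 from the plain phenyl of compound 1 or the 4-methylphenyl of compound 2. Nothing measured here explains why only the 4-(dimethylamino)phenyl of compound 3 stands apart.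

Compound 3 and compound 4 differ in both the group and where it sits on the phenyl, so these two effects cannot be separated. From the compounds shown here alone, how 4-chlorophenyl, 4-aminophenyl or 4-methoxyphenyl would behave at this position remains open.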